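Removing One Fluorine from a Legumain Inhibitor

The compounds below may be only part of what the source reports. "The series", "measured", "known", "first", "only" and "open" are said of these compounds alone.

Of the compounds shown here, three have so far been tested in an assay on isolated protein for inhibition of legumain (Homo sapiens), with stated times of 2 min and 60 min; a lower number here means a stronger inhibitor, a higher number a weaker inhibitor. Compound 1 `CC(C)CS(=O)(=O)N(Cc1ccc(-c2cccc(F)c2)cc1)[C@@H](C)C(=O)N[C@H](C#N)CC(N)=O` gives 2270 nM, compound 3 `CC(C)CS(=O)(=O)N(Cc1ccc(-c2cccc(F)c2F)cc1)[C@@H](C)C(=O)N[C@H](C#N)CC(N)=O` gives 1820 nM, and compound 2 `C[C@@H](C(=O)N[C@H](C#N)CC(N)=O)N(Cc1ccc(-c2ccc(F)c(F)c2)cc1)S(C)(=O)=O` gives 252 nM, the lowest of the three. The difference between the core of compound 2 and the core of compound 3 is not broken down here. From compound 3 to compound 1 the change is hydrogen in place of fluoro on an aromatic carbon, and it produced a 1.2-fold higher number from compound 3 to compound 1 (0.10 log units; within the scatter). Compound 4 `C[C@@H](C(=O)N[C@H](C#N)CC(N)=O)N(Cc1ccc(-c2ccc(F)cc2)cc1)S(C)(=O)=O` has not yet been measured; it differs from compound 2 by hydrogen in place of fluoro on an aromatic carbon. This is the same kind of change, though the surroundings differ: in compound 3 the carbon is ortho to a large group, in compound 2 it is meta to a large group. Compound 4 is expected to show a small step, a 1.3-fold higher number from compound 2 to compound 4 (0.12 log units; within the scatter), in this assay because the earlier change gave a 1.2-fold higher number from compound 3 to compound 1 (0.10 log units; within the scatter). Compound 4 is therefore estimated at 330 nM, likely between 150 nM and 750 nM.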

Compound 4, half-maximal inhibitory concentration: 1040 nM
Compound 4: middle estimate off by 3.2-fold (0.50 log units), on the low side; the measured number lies above the stated range.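

In this assay, hydrogen in place of fluoro on an aromatic carbon gave a 4.1-fold higher number from compound 2 to compound 4 (0.62 log units; beyond the scatter), so in this pair the change from 3,4-difluorophenyl to 4-fluorophenyl is not silent. The size of the step did not carry over from one core to the other: the same change on two cores in this assay, a 1.2-fold higher number (0.10 log units; within the scatter) from compound 3 to compound 1 and a 4.1-fold higher number (0.62 log units; beyond the scatter) from compound 2 to compound 4, 3.3-fold (0.52 log units) apart, beyond the scatter of two such steps What this does not show is whether the core or the place of the fluoro accounts for the gap, as the two pairs differ in both, and two pairs give no rule for the series.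

Still open, on these data alone, is how the step would read with a chloro, methyl or methoxy group on that carbon in place of fluoro. Also open, as far as these compounds go, is whether the change from 3,4-difluorophenyl to 4-fluorophenyl gives the same step on the core of compound 1.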